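The source may hold more compounds than are shown below. What is called first, only, known or untested is meant among the compounds shown, and "the series" means these compounds.

Among the compounds with values here, in a functional assay on SW480 cells (Homo sapiens) for inhibition (on this read-out lower numbers stand for stronger inhibition and higher numbers for weaker inhibition), compound 1 `CN[C@@H](C#Cc1c(F)ccc2c1/C(=C/c1[nH]ccc1OC)C(=O)N2)CO` gives 80 nM, the lowest of the three numbers measured so far. Compound 2 `CCN[C@H](C#Cc1c(F)ccc2c1/C(=C/c1[nH]ccc1OC)C(=O)N2)CO` gives 566 nM, and compound 3 `COc1cc[nH]c1/C=C1\C(=O)Nc2ccc(F)c(C#C[C@@H](N)[C@@H](C)O)c21` gives 210 nM. Compound 4 `COc1cc[nH]c1/C=C1\C(=O)Nc2ccc(F)c(C#C[C@@H]3C[C@@H](O)CN3)c21` has not yet been measured; it differs from compound 1 by 4-hydroxypyrrolidin-2-yl in place of 2-hydroxy-1-(methylamino)ethyl on a triple-bonded carbon. Both measured steps alter this same group on the triple-bonded carbon, and both weaken inhibition: a 7.1-fold higher number from compound 1 to compound 2 (0.85 log units; beyond the scatter) and a 2.6-fold higher number from compound 1 to compound 3 (0.42 log units; beyond the scatter). Closing the chain into a ring is a different kind of alteration, but each change of this group seen so far has cost potency, so for compound 4 a modest weakening is expected, a 2.5-fold higher number from compound 1 to compound 4 (0.40 log units; beyond the scatter). Compound 4 is therefore estimated at 200 nM, with a range from 60 nM to 650 nM.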

Compound 4, half-maximal inhibitory concentration: 44 nM
Estimate against measurement, compound 4: 4.5-fold (0.66 log units) above; the measured number lies below the stated range.
By their numbers in this assay, from the lowest: compounds 4 and 1 (each within the scatter of the next); then compound 3; then compound 2.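

In this assay a ring on the triple-bonded carbon is accepted: with a 1.8-fold lower number from compound 1 to compound 4 (0.26 log units; within the scatter) the 4-hydroxypyrrolidin-2-yl group holds level with the open 2-hydroxy-1-(methylamino)ethyl chain, the first change of this group shown that costs no potency. Against the other two open chains, the ring gives a 4.8-fold lower number from compound 3 to compound 4 (0.68 log units; beyond the scatter) and a 13-fold lower number from compound 2 to compound 4 (1.11 log units; beyond the scatter) in clear gains. No measured evidence accounts for this.
From the compounds shown here alone, whether the ring's hydroxyl is needed stays open, as a plain pyrrolidin-2-yl group would test. So does whether a larger ring, such as piperidin-2-yl, would serve equally well.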